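Chloro for methyl on the fused ring of compound 1

The source may report more compounds than this note shows. Statements on the series, on what has been measured and on what is new or still open speak of the compounds shown alone.

Compound 1 `CCN(CC)CCCn1c(=O)c(=Cc2cc(OC)c(OC)c(OC)c2)s/c1=C1\C(=O)Nc2ccc(C)cc21` carries the trimethoxyphenyl group on the double-bonded chain carbon. In a functional assay on HT-29 cells (Homo sapiens) for inhibition, read by MTT assay, with a stated time of 72 h (on this read-out higher numbers stand for weaker inhibition and lower numbers for stronger inhibition), compound 1 gives only a limit, > 200000 nM, and no number. Compound 2 `CCN(CC)CCCn1c(=O)c(=Cc2ccc(O)cc2)s/c1=C1\C(=O)Nc2ccc(C)cc21` gives 770 nM in this assay, and compound 3 `CCN(CC)CCCn1c(=O)c(=Cc2ccccc2O)s/c1=C1\C(=O)Nc2ccc(C)cc21` gives 8070 nM. Both changes at the pendant aryl move the read-out a long way: an at least 250-fold lower number from compound 1 to compound 2 (2.41 log units; beyond the scatter) and an at least 24-fold lower number from compound 1 to compound 3 (1.39 log units; beyond the scatter); between the two hydroxyphenyl members, a 10-fold higher number from compound 2 to compound 3 (1.02 log units; beyond the scatter). Compound 1 thus stands at the weak end of the three, at the limit of > 200000 nM in this assay, at which 1 of the 3 values shown sits.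

Compound 4 `CCN(CC)CCCn1c(=O)c(=Cc2cc(OC)c(OC)c(OC)c2)s/c1=C1\C(=O)Nc2ccc(Cl)cc21` keeps the trimethoxyphenyl group and the rest of the shared core and differs from compound 1 only in that (chloro in place of methyl on an aromatic carbon), on the six-membered carbon-only aromatic ring of the fused system, meta and para to a fused ring. For the measured compounds named here, none of the measured steps touches this ring; all three alter the pendant aryl and so say nothing direct about exchanging methyl for chloro here. Going by the values given here, with no step bearing on the change, no move beyond the scatter is expected, and compound 4 is expected to remain at the limit in this assay. For compound 4 the estimated step is a number no higher from compound 1 to compound 4 (the limit leaves the size open). Compound 4 is expected near 200000 nM, with a range from 80000 nM to 500000 nM.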

Compound 4, half-maximal inhibitory concentration: > 200000 nM
Compound 4: no number, only a limit; the forecaster's own chance of this, stated with the estimate: 75%; the middle value sits exactly at the limit.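

In this assay, compound 1 and compound 4 both give only a limit and no number, so the step between them cannot be read: the limit of > 200000 nM in this assay, at which 2 of the 4 values shown sit.

The compounds shown leave open what chloro in place of methyl on an aromatic carbon does to the read-out, whether with the trimethoxyphenyl group or with either hydroxyphenyl group.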